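The source may report more compounds than this note shows. Statements on the series, on what has been measured and on what is new or still open speak of the compounds shown alone.

The measured compounds:
compound 1, `CC(C#Cc1cccc(C(=O)NCc2ccccc2C(F)(F)F)c1)N(O)C(N)=O`: 700 nM
compound 2, `CC(C#Cc1cccc(C(=O)NCc2ccc(F)cc2C(F)(F)F)c1)N(O)C(N)=O`: 1300 nM
compound 3, `C[C@@H](C#Cc1cccc(C(=O)NCc2ccccc2C(F)(F)F)c1)N(O)C(N)=O`: 700 nM

In an assay for inhibition of Polyunsaturated fatty acid 5-lipoxygenase (Homo sapiens), read by HPLC, with stated times of 15 min and 10 min (a lower number here means a stronger inhibitor, a higher number a weaker inhibitor), compound 1 gives 700 nM. Compound 1 is level with compound 3 at the digits shown, and together they have the lowest of the three numbers; compound 2 lies furthest from compound 1, with a 1.9-fold higher number from compound 1 to compound 2 (0.27 log units; within the scatter). Between compound 1 and compound 3 there is no change at the digits printed from compound 1 to compound 3 (within the scatter), the two differing only in the fact that one of compounds 1 and 3 is drawn with a defined configuration and the other without, at the place where they differ.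

Compound 4, `CC(C#Cc1cccc(C(=O)NCc2ccccc2OC(F)(F)F)c1)N(O)C(N)=O`, is not yet measured. It departs from compound 1 by trifluoromethoxy in place of trifluoromethyl on an aromatic carbon, placed on an aromatic carbon of a six-membered aromatic ring of carbon only, ortho to a large group. For the measured compounds named here, neither measured step touches this change: the fluoro step and the stereo step both stayed within the scatter, and nothing among the measured compounds probes the trifluoromethyl group itself. The expected step in this assay is therefore none beyond the scatter, a 1.3-fold higher number from compound 1 to compound 4 (0.11 log units; within the scatter). Compound 4 is estimated at 900 nM, with a range from 350 nM to 2500 nM.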

Compound 4, half-maximal inhibitory concentration: 1000 nM
The estimate for compound 4 lay 1.1-fold (0.05 log units) below the measured number; the measured number falls inside the stated range.
By their numbers in this assay, from the lowest: compounds 1, 3, 4 and 2 (each within the scatter of the next).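

In this assay, the change from trifluoromethyl to trifluoromethoxy on an aromatic carbon, ortho to a large group, is the first among these compounds to alter that group itself, and it gives a 1.4-fold higher number from compound 1 to compound 4 (0.15 log units; within the scatter). This place on the ring therefore takes the larger trifluoromethoxy group, with its oxygen, without a step beyond the scatter. Nothing measured here offers a reason for this outcome, and the only stereochemical observation does not bear on it.

The compounds shown leave open whether a methoxy group, a chlorine or a nitrile at this place, or simple hydrogen, would move the number beyond the scatter. They also leave open whether trifluoromethoxy behaves the same way alongside the ring fluoro of compound 2 or with the configuration drawn in compound 3.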